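Aminopyrrolidinyl-ethyl ether in place of piperidinyl ether

The source may report more compounds than this note shows. Statements on the series, on what has been measured and on what is new or still open speak of the compounds shown alone.

Compound 1 `Clc1ccc(Oc2ccc3nc(-c4ccc(OCC5CCNCC5)cc4)oc3c2)cc1` in an assay on isolated protein for inhibition of advanced glycosylation end product-specific receptor (Homo sapiens), read by FRET, with stated times of 30 min and 1 h, tested at 4 uM (a higher number here means more inhibition at the concentration tested (going by the name of the read-out), a lower number less inhibition), gives "not active" (no number reported), which is a report without a number; compound 1 therefore stands at the bottom of the numbers shown, alongside compound 3 `Clc1ccc(Oc2ccc3nc(-c4ccc(OCCCN5CCCC5)cc4)oc3c2)cc1`, which in this assay also gives "not active" (no number reported). Compound 2 `CC(C)N1CCC(Oc2ccc(-c3nc4ccc(Oc5ccc(Cl)cc5)cc4o3)cc2)CC1` in this assay gives 12.7%, a small value. Compound 4 `N[C@@H]1CCN(CCCOc2ccc(-c3nc4ccc(Oc5ccc(Cl)cc5)cc4o3)cc2)C1` has not yet been measured. The change from compound 1 to compound 4: 2-(3-aminopyrrolidin-1-yl)ethyl in place of piperidin-4-yl on a saturated chain carbon bound to an oxygen on an aromatic ring. Among the measured compounds shown here, no pair of measured compounds differing in one place is available, so no step size can be read from the data. For the measured compounds named here, since compound 1 gives "not active" (no number reported) and no compound in the set rises beyond the small value of compound 2, the expected step for compound 4 in this assay is none beyond the scatter. Compound 4 is estimated at 6%, between -5% and 20%.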

Compound 4, a percentage reported as inhibition, at one concentration (the size of the read-out at that concentration, not a potency): 19.6%
For compound 4 the middle estimate is 13.6 percentage points below the measured one; measured number inside the range.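

In this assay, 3-(3-aminopyrrolidin-1-yl)propyl in place of 1-isopropylpiperidin-4-yl on an oxygen on an aromatic ring gives a number 6.9 percentage points higher from compound 2 to compound 4 (within the scatter), so this exchange leaves the reading unresolved from that of compound 2. Steps to compound 1 and compound 3 cannot be read, since neither has a number. Nothing available accounts for the result. Going by these compounds, whether a morpholine or a carboxylic acid at the end of the propoxy chain would move the reading beyond the scatter stays open. On these data alone, the mirror-image 3-aminopyrrolidine also stays open.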